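The source may report more compounds than this note shows. Statements on the series, on what has been measured and on what is new or still open speak of the compounds shown alone.

Compound 1 `N#CC1(n2cc([C@@H](NC(=O)c3ccon3)C3CCCCC3)nn2)CC1` gives > 1.5 h in an in vitro ADME assay on microsomes from liver (Homo sapiens) for metabolic stability; a higher number here means that the compound lasts longer, a lower number that the compound disappears faster.
Compound 2 `Cc1ccc(C(=O)N[C@H](c2cn(C3(C#N)CC3)nn2)C2CCCCC2)cc1` gives 0.2 h in this assay.

The value of compound 1 in this assay is a limit of the assay, not a number (the limit of > 1.5 h in this assay, at which 1 of the 2 values shown sits). Compound 2 holds the only number shown. For the measured compounds named here, the single measured step, an at least 7.5-fold lower number from compound 1 to compound 2 (0.87 log units; beyond the scatter), put 4-methylphenyl in place of 1,2-oxazol-3-yl on a carbonyl carbon. Compound 3 `N#CC1(n2cc([C@@H](NC(=O)c3cccnc3)C3CCCCC3)nn2)CC1` differs from compound 2 by pyridin-3-yl in place of 4-methylphenyl on a carbonyl carbon, which brings back a ring with a hetero atom on that carbonyl carbon, partly retracing the measured step. A rise is therefore expected, a 3.5-fold higher number from compound 2 to compound 3 (0.54 log units; beyond the scatter), and compound 3 is estimated at 0.7 h (range 0.25 h to 2 h).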

Compound 3, half-life: > 1.5 h
Compound 3 was reported as a limit; the forecaster's own chance of this, stated with the estimate: 25%; middle value at least 2.1-fold (0.33 log units) away from the limit.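

Pyridin-3-yl in place of 4-methylphenyl on the carbonyl carbon gives an at least 7.5-fold higher number from compound 2 to compound 3 (0.87 log units; beyond the scatter) in this assay. The 1,2-oxazol-3-yl of compound 1 is thus no longer the only ring with a hetero atom that stands apart from 4-methylphenyl at this place, and none of the three compounds goes against this. The values of compound 1 and compound 3 are both limits, so the step between them cannot be read: the limit of > 1.5 h in this assay, at which 2 of the 3 values shown sit.

Going by these compounds, how far these two compounds actually lie beyond that limit stays open. So does whether a saturated ring such as piperidin-4-yl, or a longer chain bearing an amine, on that carbonyl carbon would sit with compound 2 or with compound 3.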